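The source may hold more compounds than are shown below. What is called first, only, known or untested is meant among the compounds shown, and "the series" means these compounds.

Measured so far:
compound 1, `CCn1c(SCC(=O)Nc2ccc(/C(C)=N/O)cc2)nnc1-c1ccc(OC)c(OC)c1`, with 65% in a functional assay on the whole organism (strain albino) for inhibition, with Rattus norvegicus as the target, read by paw edema, with stated times of 30 min and 2 h, at a dose of 0.28 mmol/kg by the oral route; a lower number here means less inhibition, a higher number more inhibition at the dose given (going by the name of the read-out);
compound 2, `CCn1c(SCC(=O)Nc2ccc(/C(C)=N/O)cc2)nnc1-c1ccc(OC)cc1`, with 58% in this assay.

Among the measured compounds shown here, compound 1 holds the higher of the two numbers, with compound 2 the nearest; the only step between them, hydrogen in place of methoxy on an aromatic carbon, gives a number 7 percentage points lower from compound 1 to compound 2 (within the scatter), so the two values stand within the scatter of each other and no order between them can be claimed.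

Compound 3, `CCn1c(SCC(=O)Nc2ccc(C(C)=O)cc2)nnc1-c1ccc(OC)c(OC)c1`, has not yet been measured. It differs from compound 1 in a single place: a group of 3 heavy atoms (2 carbon, 1 oxygen; no ring) in place of a group of 4 heavy atoms (2 carbon, 1 nitrogen, 1 oxygen; no ring), on an aromatic carbon. For the measured compounds named here, no measured step touches this part of the molecule; the one step on record, from compound 1 to compound 2, concerns the methoxy on the other aromatic ring and was within the scatter. The data therefore give no direction for the change from compound 1 to compound 3, and the expectation rests on compound 1 alone.

On that basis, compound 3 is expected to give 57% in this assay, within a range from 38% to 72%. This estimate means a step of a number 8 percentage points lower from compound 1 to compound 3 (within the scatter), expected to lie within the scatter, with the wide range reflecting that nothing measured bears on this change.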

Compound 3, a percentage reported as inhibition, in the whole organism at one dose (the size of the read-out at that dose, not a potency): 59%
The estimate for compound 3 lay 2 percentage points below the measured number; low and high end bracket the measured number.
By their numbers in this assay, from the lowest: compounds 2, 3 and 1 (each within the scatter of the next).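

At the aromatic carbon para to a large group, on the six-membered aromatic ring of carbon only, the compounds now include a change in this assay: acetyl in place of the group of 4 heavy atoms gives a number 6 percentage points lower from compound 1 to compound 3 (within the scatter). The group that leaves has 1 hydrogen-bond donor and 2 hydrogen-bond acceptors, while acetyl has 0 donors and 1 acceptor, so at this single dose, inhibition of paw edema does not depend measurably on having the group of 4 heavy atoms rather than acetyl at this position. Nothing available bears on why the two numbers stand within the scatter of each other.

Among the compounds shown here, it remains open whether an amine, a carboxylic acid or a longer chain at this position would also stay within the scatter of compound 1, since only two groups are compared here. From the compounds shown here alone, it is also open whether the two compounds would stay this close at other doses, and what acetyl would give on the core of compound 2, which has hydrogen in place of the methoxy.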